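The source may report more compounds than this note shows. Statements on the series, on what has been measured and on what is new or still open speak of the compounds shown alone.

The account concerns compound 1 `N#Cc1ccc(NC(=S)N/N=C/c2ccc3ccccc3n2)cc1` and the compound made from it by a single exchange, compound 4 `S=C(N/N=C/c1ccc2ccccc2n1)Nc1cccc(Cl)c1`. In a functional assay on HT-29 cells (Homo sapiens) for antiproliferative activity, read by sulforhodamine B assay, with a stated time of 72 h (a lower number here means a stronger inhibitor, a higher number a weaker inhibitor), compound 1 gives 15600 nM, the second highest of the three numbers recorded. Nearest to it stands compound 2 `NC(=S)N/N=C/c1cc2ccccc2s1`, which gives 99200 nM; furthest stands compound 3 `CN(C)C(=S)N/N=C/c1nc2ccccc2s1`, which gives 250 nM. Both gaps lie beyond the scatter. The change from compound 1 to compound 4 is 3-chlorophenyl in place of 4-cyanophenyl on an amide-type nitrogen. Among the measured compounds shown here, no measured pair shows this exchange, so the expected size of its step rests on nothing beyond compound 1 itself. A small step, at most near the edge of the scatter, is expected, estimated as a 1.6-fold lower number from compound 1 to compound 4 (0.19 log units; within the scatter). Compound 4 is therefore estimated in this assay at 10000 nM, with a range from 3000 nM to 40000 nM.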

Compound 4, half-maximal inhibitory concentration: 48100 nM
Estimate against measurement, compound 4: 4.8-fold (0.68 log units) below, and the stated range ends below it.
By their numbers in this assay, from the lowest: compound 3; then compound 1; then compound 4; then compound 2.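

Among the compounds shown here, compound 1 and compound 4 give the first measured reading of this position, the amide-type nitrogen whose other neighbour is the thiocarbonyl carbon. In this assay the exchange of 4-cyanophenyl for 3-chlorophenyl gives a 3.1-fold higher number from compound 1 to compound 4 (0.49 log units; beyond the scatter) and so moves towards weaker inhibition, showing that the group on this nitrogen can shift the number beyond the scatter. Nothing at hand bears on why this step occurs. The exchange alters both the substituent and its ring position, so the two remain unseparated. Plain phenyl, 4-chlorophenyl or 3-cyanophenyl on this nitrogen would be the open comparisons.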